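Cycloheptyl in place of cyclopentyl in compound 1

This account rests on a few compounds, and the source may have more. Where it says the series, first, only, none or still open, it means among the compounds named here.

Going by the values given here, in a functional assay on BXPC-3 cells (Homo sapiens) for cytotoxicity, read by fluorescence, with a stated time of 48 h (on this read-out lower numbers stand for an effect already at smaller amounts and higher numbers for an effect only at larger amounts of compound), compound 1 `CC(C)=CCC/C(C)=C/CC/C(C)=C/CSC[C@H](NC(=O)CCCCCN1CCCC1)C(=O)NC1CCCC1` gives 6800 nM as the only true number so far. Compound 2 `CC(C)=CCC/C(C)=C/CC/C(C)=C/CSc1ccccc1C(N)=O` returns > 20000 nM in this assay, and this value is a limit of the assay. Compound 3 `CC(C)=CCC/C(C)=C/CC/C(C)=C/CSC[C@H](NC(=O)CCCCCN1CCCC1)C(=O)NC1CCCCCC1` keeps the core of compound 1 and carries cycloheptyl in place of cyclopentyl on an amide-type nitrogen and has not yet been measured. Among the compounds with values here, no measured pair shows what a change of this kind does. In this assay the expectation is therefore a small change, perhaps towards a slightly lower number, and not clearly beyond the usual scatter. The estimated step of a 1.4-fold lower number from compound 1 to compound 3 (0.13 log units; within the scatter) is expected to remain modest. The expected value for compound 3 is 5000 nM with a range from 2000 nM to 14000 nM on this estimate.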

Compound 3, half-maximal effective concentration: 5800 nM
Beside the measured number, compound 3's estimate is 1.2-fold (0.06 log units) below it; the measured number falls inside the stated range.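

In this assay, going by these compounds alone, the first pair that differs in one place gives a 1.2-fold lower number from compound 1 to compound 3 (0.07 log units; within the scatter), so cyclopentyl and cycloheptyl on an amide-type nitrogen cannot be told apart on this read-out. The earlier compounds shown here could not show that this position accepts a seven-membered non-aromatic ring of carbon only in place of a five-membered one with no step beyond the scatter. Compound 2 remains the only compound at a limit of the assay, and that entry is a limit, not a number: the limit of > 20000 nM in this assay, at which 1 of the 3 values shown sits.

On these data alone, whether a phenyl ring, an open-chain tert-butyl group or a cycloheptyl ring carrying an amine or a carboxylic acid on this nitrogen would behave the same stays open. A single pair also cannot establish a trend with ring size.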